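The source may report more compounds than this note shows. Statements on the series, on what has been measured and on what is new or still open speak of the compounds shown alone.

Measured compounds in this series:

Compound 1, `Cc1ccc(NC(=O)CCc2cn(Cc3ccc4oc(-c5ccccc5)cc(=O)c4c3)nn2)cc1`: 15600 nM
Compound 2, `O=C(CCc1cn(Cc2ccc3oc(-c4ccccc4)cc(=O)c3c2)nn1)Nc1ccccc1`: 15600 nM
Compound 3, `Cc1ccc(NC(=O)CCc2cn(Cc3ccc4oc(-c5ccc(Cl)cc5)cc(=O)c4c3)nn2)cc1`: 32900 nM

All three numbers come from an assay on isolated protein for inhibition of Amine oxidase [flavin-containing] B (Homo sapiens), read by fluorescence and spectrophotometry; a lower number here means a stronger inhibitor, a higher number a weaker inhibitor. Within the pair compound 1 and compound 2, the change is hydrogen in place of methyl on an aromatic carbon, and the step is no change at the digits printed from compound 1 to compound 2 (within the scatter). Within the pair compound 1 and compound 3, the change is chloro in place of hydrogen on an aromatic carbon, and the step is a 2.1-fold higher number from compound 1 to compound 3 (0.32 log units; beyond the scatter), leaving compound 3 with the highest number of the three.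

Compound 4, `O=C(CCc1cn(Cc2ccc3oc(-c4ccc(Cl)cc4)cc(=O)c3c2)nn1)Nc1ccccc1`, is not yet measured in this assay. It differs from compound 3 by hydrogen in place of methyl on an aromatic carbon, which is the same change that took compound 1 to compound 2, on the same place. The core of compound 4 is that of compound 3; how this core differs from the core of compound 1 is given by chloro in place of hydrogen on an aromatic carbon above.

For compound 4 the expected step is a 1.0-fold higher number from compound 3 to compound 4 (0.00 log units; within the scatter), resting on compound 1 and compound 2, whose step no change at the digits printed from compound 1 to compound 2 (within the scatter) stayed within the scatter. Compound 4 is therefore estimated at 33000 nM, with a range from 16000 nM to 66000 nM.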

Compound 4, half-maximal inhibitory concentration: 32900 nM
Estimate against measurement, compound 4: 1.0-fold (0.00 log units) above; the range from low to high includes it.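

Replacing methyl with hydrogen on the 4-methylphenyl group of the chloro-bearing core in this assay gives no change at the digits printed from compound 3 to compound 4 (within the scatter), matching the step on the core without chloro: the same change on two cores in this assay, no change at the digits printed (within the scatter) from compound 1 to compound 2 and no change at the digits printed (within the scatter) from compound 3 to compound 4, 1.0-fold (0.00 log units) apart, within the scatter of two such steps. The chloro step also carries over, with a 2.1-fold higher number from compound 2 to compound 4 (0.32 log units; beyond the scatter) on the phenylcarbamoyl compounds: the same change on two cores in this assay, a 2.1-fold higher number (0.32 log units; beyond the scatter) from compound 1 to compound 3 and a 2.1-fold higher number (0.32 log units; beyond the scatter) from compound 2 to compound 4, 1.0-fold (0.00 log units) apart, within the scatter of two such steps. The two changes therefore act independently across these four compounds, but this single square shows nothing about other cores or other groups.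

Open, on these data alone, is whether an amine or a carboxylic acid in place of the methyl would leave the number equally unmoved. Also open, as far as these compounds go, is whether a longer chain between the triazole and the amide would alter either step.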